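A few compounds are considered here, and "the series" means these few. Any claim that something is new, unique, unknown or untested is made for them only; others in the source may bear on it.

Working notes on the series.

Of the compounds shown here, three have been measured in an assay on HepG2 cells for activation of nuclear factor erythroid 2-related factor 2 (Homo sapiens), read by a luciferase reporter, with a stated time of 5 h; a lower number here means that less compound is needed, a higher number that more compound is needed for the effect. Among the compounds with values here, compound 1 `COc1ccc(/C=C/c2ccc(F)cc2)cc1` is the only one to return a number: in this assay compound 1 gives 4200 nM. Compound 3 `COc1ccc(/C=C/c2ccc(F)c(F)c2)cc1` sits at a limit of this assay, > 15000 nM. Compound 2 `Fc1ccc(/C=C/c2ccccc2F)cc1F` also sits at a limit of this assay, > 15000 nM.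

Within the data shown here, only one step can be sized. From compound 3 to compound 1 the change is hydrogen in place of fluoro on an aromatic carbon, and in this assay it gives an at least 3.5-fold lower number from compound 3 to compound 1 (0.55 log units; beyond the scatter), read against (the limit of > 15000 nM in this assay, at which 2 of the 3 values shown sit).

Compound 4 `Fc1ccc(/C=C/c2ccccc2F)cc1` is not yet measured. It differs from compound 2 by hydrogen in place of fluoro on an aromatic carbon. The cores of compound 2 and compound 3 differ, but that difference is not broken down here. The change from compound 2 to compound 4 is therefore the same kind of change as that from compound 3 to compound 1, not the same: around the place, the hydrogen enters meta to a group of 9 heavy atoms in compound 4, whereas in compound 1 it enters meta to a large group.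

Starting from a limit, any numerical value for compound 4 would already be a step downward. A step of an at least 1.8-fold lower number from compound 2 to compound 4 (0.27 log units; that floor lies within the scatter) is expected, and that expectation rests on the measured step of an at least 3.5-fold lower number from compound 3 to compound 1 (0.55 log units; beyond the scatter) and on compound 2 standing at the limit of > 15000 nM in this assay, at which 2 of the 3 values shown sit. For compound 4 the expected value in this assay is 8000 nM, with a plausible range from 3000 nM to 20000 nM.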

Compound 4, half-maximal effective concentration: 3600 nM
Estimate against measurement, compound 4: 2.2-fold (0.35 log units) above; the range from low to high includes it.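

In this assay, hydrogen in place of fluoro on an aromatic carbon, ortho to a fluoro group and meta to a group of 9 heavy atoms, gives an at least 4.1-fold lower number from compound 2 to compound 4 (0.61 log units; beyond the scatter). Set beside the earlier step on another core, the change carries over in direction, with a lower number on both cores, but the data do not settle whether its size carries over: the same change on two cores in this assay, an at least 3.5-fold lower number (0.55 log units; beyond the scatter) from compound 3 to compound 1 and an at least 4.1-fold lower number (0.61 log units; beyond the scatter) from compound 2 to compound 4; the limit leaves it open whether they differ. Within the data shown here, this rests on only two cores, and each step starts from a limit and not from a number, so neither step has a known full size: the limit of > 15000 nM in this assay, at which 2 of the 4 values shown sit.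

The compounds shown leave open what an amine, a hydroxyl group or a carboxylic acid would do at this place in this assay, as only fluoro and hydrogen are compared there. Also open, from the compounds shown here alone, are whether the change holds on any core beyond these two, and whether replacing the remaining fluoro groups of compound 4 with hydrogen would move the number further.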